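The source may report more compounds than this note shows. Statements on the series, on what has been measured and on what is new or still open speak of the compounds shown alone.

Series notes. Compound 1 `CN1CCN(CC(=O)Nc2nc3ccccc3[nH]2)CC1` gives 45% in a functional assay, read by spectrophotometry, with a stated time of 30 min, tested at 100 ug/mL; on this read-out higher numbers stand for a stronger effect at the one concentration tested and lower numbers for a weaker effect. Compound 2 `CCN1CCN(CC(=O)Nc2nc3ccccc3[nH]2)CC1` gives 45.7% in this assay, with the step of a number 0.7 percentage points higher from compound 1 to compound 2 (within the scatter). Compound 3 `O=C(CN1CCN(c2ccccc2)CC1)Nc1nc2ccccc2[nH]1` gives 32.2% in this assay, the lowest of the three numbers, reached by a number 12.8 percentage points lower from compound 1 to compound 3 (beyond the scatter) and by a number 13.5 percentage points lower from compound 2 to compound 3 (beyond the scatter). Compound 4 `O=C(CN1CCN(c2ccccc2F)CC1)Nc1nc2ccccc2[nH]1` differs from compound 3 only by fluoro in place of hydrogen on an aromatic carbon. Going by the values given here, no measured step touches the phenyl itself; the steps in hand alter the group on the ring nitrogen, where phenyl in place of methyl or ethyl cost a modest amount, and methyl in place of hydrogen on the chain carbon changed nothing beyond the scatter. For compound 4 the step of a number 0.2 percentage points lower from compound 3 to compound 4 (within the scatter) is therefore expected to stay within the scatter. Compound 4 is estimated at 32%, range 18% to 46%.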

Compound 4, a percentage reported as activity, at one concentration (the size of the read-out at that concentration, not a potency): 47.7%
Compound 4: the middle estimate sits 15.7 percentage points below what was measured; the measured number lies above the stated range.
By their numbers in this assay, from the lowest: compound 3; then compounds 1, 2 and 4 (each within the scatter of the next).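

In this assay the phenyl itself turns out to respond: a number 15.5 percentage points higher from compound 3 to compound 4 (beyond the scatter) follows from fluoro in place of hydrogen on an aromatic carbon, ortho to a large group. The cost seen with phenyl on the ring nitrogen does not carry over to 2-fluorophenyl, with a number 2 percentage points higher from compound 2 to compound 4 (within the scatter) and a number 2.7 percentage points higher from compound 1 to compound 4 (within the scatter) as its steps. Nothing at hand accounts for this recovery. Open, from the compounds shown here alone, is whether chloro, methoxy or a nitrile at the same place would behave like fluoro, and whether fluoro on another aromatic carbon of the phenyl would give a similar step.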